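Side-chain exchange on the shared core: compound 3

The source may report more compounds than this note shows. Statements on the series, on what has been measured and on what is new or still open speak of the compounds shown alone.

In a functional assay on L1210 cells (Mus musculus), with a stated time of 12 days (a lower number here means a less potent compound, a higher number a more potent compound, by a factor of ten per unit of this negative logarithm), compound 1 `CC1=C(N2CC2)C(=O)C(CC(C)OC(N)=O)=C(N2CC2)C1=O` gives 5.79, and compound 2 `CC1=C(N2CC2)C(=O)C(CCCOC(N)=O)=C(N2CC2)C1=O` gives 5.93. Compound 2 stands with the larger of the two numbers shown, the step between the two measured compounds being a number 0.14 log units higher from compound 1 to compound 2 (within the scatter). Compound 3 `CC1=C(N2CC2)C(=O)C(CCCc2ccccc2)=C(N2CC2)C1=O` differs from compound 2 by phenyl in place of carbamoyloxy on a saturated chain carbon, three bonds along the chain from a double-bonded ring carbon. For the measured compounds named here, the single measured step, a number 0.14 log units higher from compound 1 to compound 2 (within the scatter), concerns another exchange at the same chain and lies within the scatter, so no measured step bears directly on this change, and the expectation rests on no more than the two values shown. Compound 3 is estimated at 5.6, with a range from 4.9 to 6.3. The expected step is a number 0.33 log units lower from compound 2 to compound 3 (beyond the scatter), a direction not settled by the data.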

Compound 3, logarithm of the reciprocal of the active concentration, log(1/C): 4.21
Beside the measured number, compound 3's estimate is 1.39 log units above it; measured number outside the range, below it.
By their numbers in this assay, from the lowest: compound 3; then compounds 1 and 2 (each within the scatter of the next).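

Unlike the earlier exchange on this chain, which stayed within the scatter, this change moves the read-out clearly in this assay: phenyl in place of carbamoyloxy gives a number 1.72 log units lower from compound 2 to compound 3 (beyond the scatter). The wider exchange on the chain gives a drop of similar size, a number 1.58 log units lower from compound 1 to compound 3 (beyond the scatter), so the chain end matters here, at least for these compounds. No measurement shown explains the drop.

On these data alone, it remains open whether the loss comes from removing carbamoyloxy or from introducing phenyl. A chain ending in a hydroxyl group or an amine would help separate the two.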